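Amide replacement on the aryl carbonyl of compound 2

The source may hold more compounds than are shown below. What is called first, only, known or untested is meant among the compounds shown, and "the series" means these compounds.

Compound 1 `NC(=O)Nc1sc(-c2ccccc2)cc1C(=O)Nc1ccccc1` belongs to the series, but in a functional assay on HT-29 cells (Homo sapiens) (a lower number here means that less compound is needed, a higher number that more compound is needed for the effect), compound 1 gives "not determined" (no result reported). Compound 3 `NC(=O)Nc1sc(-c2ccccc2)cc1C(=O)NC1CCNCC1` belongs to it as well, and in this assay compound 3 gives "not determined" (no result reported). Within the data shown here, compound 2 `NC(=O)Nc1sc(-c2ccc(C(=O)N3CCOCC3)cc2)cc1C(=O)N[C@H]1CCCNC1` is the only member with a number: in this assay compound 2 gives 610 nM, so it is the sole reference point and no step between measured compounds can be drawn. Compound 4 `CNC(=O)c1ccc(-c2cc(C(=O)N[C@H]3CCCNC3)c(NC(N)=O)s2)cc1` is not yet measured. It differs from compound 2 in one place (methylamino in place of morpholin-4-yl on a carbonyl carbon); in the words of that count, methylamino replaces morpholin-4-yl on a carbonyl carbon whose other neighbour is an aromatic carbon, or, cut one bond further out, methylcarbamoyl takes the place of (morpholin-4-yl)carbonyl. The rest of the structure is unchanged. Among the measured compounds shown here, with no comparable step anywhere, the change is expected to stay within the usual scatter, with no clear direction, so the step of a 1.1-fold higher number from compound 2 to compound 4 (0.06 log units; within the scatter) is estimated to be small. Compound 4 is accordingly estimated at 700 nM, with an expected range from 250 nM to 2000 nM.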

Compound 4, half-maximal effective concentration: 4300 nM
For compound 4 the middle estimate is 6.1-fold (0.79 log units) below the measured one; the measured number lies above the stated range.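

In this assay, among these compounds, this position proves sensitive to the group on the carbonyl carbon: methylamino in place of morpholin-4-yl gives a 7.0-fold higher number from compound 2 to compound 4 (0.85 log units; beyond the scatter) and is the first readable step. The change removes a ring and also exchanges a hydrogen-bond acceptor for a hydrogen-bond donor, so this one step cannot separate those differences. No available evidence bears on the reason for the step.

Going by these compounds, it remains open whether dimethylamino or piperidin-1-yl on this carbonyl carbon would read closer to compound 2 or to compound 4, which would help separate the contribution of the ring from that of the amide hydrogen. With a single step available, no trend across other groups at this position can be stated.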